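The source may hold more compounds than are shown below. What is called first, only, known or untested is meant among the compounds shown, and "the series" means these compounds.

Compound 1 `Cc1cc(C)cc(S(=O)(=O)c2c(C(=O)Nc3cccc(O)c3)[nH]c3ccc(Cl)cc23)c1` gives 24600 nM in an ADME assay on MT4 cells (Homo sapiens) for cytotoxicity, read by MTT assay; a higher number here means that more compound is tolerated, a lower number that less compound is tolerated.
Compound 2 `Cc1cc(C)cc(S(=O)(=O)c2c(C(=O)NC(C)c3ccccc3O)[nH]c3ccc(Cl)cc23)c1` gives 21800 nM.
Compound 3 `Cc1cc(C)cc(S(=O)(=O)c2c(C(=O)NCc3ccc(O)cc3)[nH]c3ccc(Cl)cc23)c1` gives 6250 nM.

Among these three numbers compound 1 stands highest, meaning it is the best tolerated, although its gap to compound 2 lies within the scatter and only compound 3 is clearly lower. Compound 4 `Cc1cc(C)cc(S(=O)(=O)c2c(C(=O)NCC(=O)NCc3ccccc3O)[nH]c3ccc(Cl)cc23)c1` differs from compound 1 in one place: a group of 12 heavy atoms (9 carbon, 1 nitrogen, 2 oxygen; one six-membered aromatic ring of carbon only) in place of a group of 7 heavy atoms (6 carbon, 1 oxygen; one six-membered aromatic ring of carbon only), on an amide-type nitrogen. Within the data shown here, two measured steps bear on this, both changes of the group on that same amide-type nitrogen: a 1.1-fold lower number from compound 1 to compound 2 (0.05 log units; within the scatter), and a 3.9-fold lower number from compound 1 to compound 3 (0.60 log units; beyond the scatter). A larger group thus gave no shift in one case and a modest drop in the other. Compound 4 is therefore estimated at about 15000 nM, within 6000 nM to 40000 nM. This expectation corresponds to a 1.6-fold lower number from compound 1 to compound 4 (0.21 log units; within the scatter).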

Compound 4, half-maximal cytotoxic concentration: > 47300 nM
Compound 4 was reported as a limit (the forecaster's own chance of this, stated with the estimate: 10%); at least 3.1-fold (0.49 log units) between middle value and limit.
By their numbers in this assay, from the lowest: compound 3; then compounds 2 and 1 (each within the scatter of the next). At a limit, above all of these: compound 4.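

In this assay compound 4 gives > 47300 nM, which is a limit and not a number. Size alone therefore does not set the number at this amide-type nitrogen, since the largest group shown goes against the drop seen with compound 3: an at least 7.5-fold higher number from compound 3 to compound 4 (0.87 log units; beyond the scatter), and an at least 2.1-fold higher number from compound 2 to compound 4 (0.33 log units; beyond the scatter). Against the smaller 3-hydroxyphenyl, the gain stays unproven: an at least 1.9-fold higher number from compound 1 to compound 4 (0.28 log units; that floor lies within the scatter).

From the compounds shown here alone, how far compound 4 lies past its limit stays unknown. The compounds shown also cannot separate the inner amide from chain length, as no longer plain carbon chain, amine or carboxylic acid stands among them.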